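The source may hold more compounds than are shown below. What is called first, only, known or untested is meant among the compounds shown, and "the series" means these compounds.

Compound 1 `CN(C)c1ccc(C2CC(c3ccc(-n4cncn4)cc3)=NN2)cc1`: 7%
Compound 2 `CN(C)c1ccc(C2CC(c3ccc(-n4ccnc4)cc3)=NN2)cc1`: 7.6%
Compound 3 `CN1CCN(c2ccc(C3=NN(S(=O)(=O)c4ccc(Br)cc4)C(c4ccc(N(C)C)cc4)C3)cc2)CC1`: 23.7%

In a functional assay on MDA-MB-231 cells (Homo sapiens) for inhibition, read by sulforhodamine B assay, tested at 10 uM (on this read-out higher numbers stand for more inhibition at the one concentration tested (going by the name of the read-out) and lower numbers for less inhibition), compound 1 gives 7%, the lowest of the three numbers. Among the measured compounds shown here, its nearest neighbour is compound 2, where the only step recorded, a number 0.6 percentage points higher from compound 1 to compound 2 (within the scatter), lies within the scatter. For the measured compounds named here, compound 3 differs from compound 1 in more than one place, so no single step is defined between them; in this assay compound 3 gives 23.7%, which simply stands beyond the scatter above compound 1.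

Compound 4 `COC(=O)CC(=O)N1N=C(c2ccc(-n3cncn3)cc2)CC1c1ccc(N(C)C)cc1` has not yet been measured. Relative to compound 1 the change is ((methoxycarbonyl)methyl)carbonyl in place of hydrogen on an amine nitrogen in a ring. Going by the values given here, none of the measured steps touches this position: the step from compound 1 to compound 2 concerns an aromatic substituent and was within the scatter, and compound 3 cannot be reduced to one change. The expectation for compound 4 therefore rests on little; a small rise is estimated, a number 7 percentage points higher from compound 1 to compound 4 (within the scatter), with wide uncertainty. Compound 4 is expected to give about 14%, estimated between 3% and 30%.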

Compound 4, a percentage reported as inhibition, at one concentration (the size of the read-out at that concentration, not a potency): 6.8%
Compound 4: the middle estimate sits 7.2 percentage points above what was measured; low and high end bracket the measured number.
By their numbers in this assay, from the lowest: compounds 4, 1 and 2 (each within the scatter of the next); then compound 3.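

In this assay, among the compounds shown here, the step at the amine nitrogen in the ring reads a number 0.2 percentage points lower from compound 1 to compound 4 (within the scatter), and this is the first step seen at this position. It shows that ((methoxycarbonyl)methyl)carbonyl, a chain with no ring and no net charge, can take the place of hydrogen on that nitrogen without a difference beyond the scatter. No measurement at hand explains this result.

As far as these compounds go, whether any other group on this nitrogen would give a number beyond the scatter of compound 1 remains open, for instance a plain acetyl, a free carboxylic acid in place of the methyl ester, or an amine at the end of a longer chain. Also open, from the compounds shown here alone, is whether the same ((methoxycarbonyl)methyl)carbonyl on compound 2 would give a similar result.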